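Removing the Bromine from Compound 3 in a Cytotoxicity Series

The compounds below may be only part of what the source reports. "The series", "measured", "known", "first", "only" and "open" are said of these compounds alone.

Compound 1 `COc1ccc(Cn2cc(/C=N\NC(=O)c3c[nH]c4ccccc34)c3ccccc32)cc1` gives 41600 nM in a functional assay on MIA PaCa-2 cells (Homo sapiens) for cytotoxicity; a higher number here means a weaker inhibitor, a lower number a stronger inhibitor.
Compound 2 `O=C(N/N=C\c1cn(Cc2ccc(Cl)cc2)c2cc(F)ccc12)c1c[nH]c2ccccc12` gives 18000 nM in this assay.
Compound 3 `COc1ccc(Cn2cc(/C=N\NC(=O)c3c[nH]c4ccc(Br)cc34)c3ccc(F)cc32)cc1` gives 45500 nM in this assay.

Compound 3 has the highest of the three numbers in this assay. Its nearest neighbour is compound 1, whose number is within the usual scatter of that of compound 3, so no order can be read between these two. Compound 2 stands further away, with a number lower than that of compound 3 by more than the scatter.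

Compound 4 `COc1ccc(Cn2cc(/C=N\NC(=O)c3c[nH]c4ccccc34)c3ccc(F)cc32)cc1` has not yet been measured in this assay. It differs from compound 3 in one place: hydrogen in place of bromo on an aromatic carbon. The difference, read one bond further out, is 5-bromo-1H-indol-3-yl to 1H-indol-3-yl.

Among the compounds with values here, no pair among the measured compounds differs in exactly this way, so there is no measured step to lean on. Compound 1, which also lacks the bromine, sits within the scatter of compound 3, and on that basis the step from compound 3 to compound 4 is expected to be small, with no direction beyond the scatter, a 1.1-fold lower number from compound 3 to compound 4 (0.03 log units; within the scatter). Compound 4 is therefore estimated at 42000 nM in this assay, within a range from 20000 nM to 90000 nM.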

Compound 4, half-maximal inhibitory concentration: 43300 nM
Beside the measured number, compound 4's estimate is 1.0-fold (0.01 log units) below it; the measured number falls inside the stated range.
By their numbers in this assay, from the lowest: compound 2; then compounds 1, 4 and 3 (each within the scatter of the next).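

In this assay, within the data shown here, the exchange of 5-bromo-1H-indol-3-yl for 1H-indol-3-yl gives a 1.1-fold lower number from compound 3 to compound 4 (0.02 log units; within the scatter), the first direct reading at this position, and it shows that bromo and hydrogen on this aromatic carbon cannot be told apart here. The same compound also links the rest of the set: fluoro in place of hydrogen on an aromatic carbon gives a 1.0-fold higher number from compound 1 to compound 4 (0.02 log units; within the scatter), again inside the scatter, while methoxy in place of chloro on an aromatic carbon gives a 2.4-fold higher number from compound 2 to compound 4 (0.38 log units; beyond the scatter), the only one of the three steps that lies beyond it, so among these four compounds only that exchange separates the numbers. Nothing accompanying these numbers explains why the bromo exchange leaves the number within the scatter.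

The compounds shown offer only bromo and hydrogen at this position, so it remains open whether an amine or a carboxylic acid on the same aromatic carbon would give a number outside the scatter. Going by these compounds, it also remains open whether bromo and hydrogen would still be indistinguishable with chloro in place of methoxy, as in compound 2.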